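A Chloro Added to an Inactive Compound

The source may report more compounds than this note shows. Statements on the series, on what has been measured and on what is new or still open speak of the compounds shown alone.

Compound 1 `O=C(CCCCC(S)CCS)NO`: 7.62%
Compound 2 `O=C(CCCCC1CCSS1)Nc1ccc(Cl)cn1`: "not active" (no number reported)
Compound 3 `O=C(CCCCC(S)CCS)Nc1ccccn1`: "not active" (no number reported)

These results come from a functional assay on KB cells (Homo sapiens) for inhibition, read by MTT assay, with a stated time of 24 h, tested at 0.1 ug/mL; on this read-out higher numbers stand for more inhibition of growth at the one concentration tested and lower numbers for less inhibition of growth. Compound 3 has no single number here, only the report "not active" (no number reported). Compound 4 `O=C(CCCCC(S)CCS)Nc1ccc(Cl)cn1` differs from it by one change: chloro in place of hydrogen on an aromatic carbon. This puts chloro in place of hydrogen on an aromatic carbon. Within the data shown here, no measured pair shows this change on its own. Compound 2 also carries chloro, and compound 2 is reported as "not active" (no number reported). In this assay, no step beyond the usual scatter is therefore expected, and a report without a number remains likely. For compound 4, the estimated value is 3%, with an expected range of 0% to 12%.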

Compound 4, percent growth inhibition at one concentration: "not active" (no number reported)
Compound 4: no number reported, so the estimate cannot be set against anything.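

Compound 3 gives "not active" (no number reported) and compound 4 gives "not active" (no number reported), so no step can be read between them. No measured evidence bears on this result. Going by these compounds, whether chloro in place of hydrogen changes growth inhibition remains open.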